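A tert-Butyl for Chloro Swap at a Limit

This account rests on a few compounds, and the source may have more. Where it says the series, first, only, none or still open, it means among the compounds named here.

The account begins with compound 1 `CN1CCN(CC(=O)NC2(c3ccc(Cl)cc3)C(=O)Nc3cc(Cl)c(Cl)cc32)CC1`, tested in an in vitro functional assay on CHO-CREluc cells for antagonist activity at growth hormone secretagogue receptor type 1 (Homo sapiens), read by a luciferase reporter, with a stated time of 4 h; a higher number here means a weaker inhibitor, a lower number a stronger inhibitor. In this assay compound 1 gives only the assay limit > 10000 nM, not a number. Compound 2 `CN(C)CCN(C)CC(=O)NC1(c2ccc(Cl)cc2)C(=O)Nc2cc(Cl)c(Cl)cc21` carries a (2-(dimethylamino)ethyl)(methyl)amino group in place of the 4-methylpiperazin-1-yl group on the saturated chain carbon bound to the carbonyl carbon. In this assay compound 2 likewise gives only a limit, > 10000 nM. The step that the two limits leave unreadable from compound 1 to compound 2 therefore cannot be read, since both ends sit at the limit of > 10000 nM in this assay, at which 2 of the 2 values shown sit. Compound 1 thus stands at the limit, with no number of its own.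

The unmeasured compound 3 `CN1CCN(CC(=O)NC2(c3ccc(C(C)(C)C)cc3)C(=O)Nc3cc(Cl)c(Cl)cc32)CC1` differs from compound 1 elsewhere: tert-butyl in place of chloro on an aromatic carbon, which one bond further out reads 4-chlorophenyl to 4-(tert-butyl)phenyl. Going by the values given here, no measured step touches this aromatic carbon, and the single measured step is unreadable, so neither direction nor size can be drawn from it. Compound 3 is therefore expected to remain near the limit, the estimated step of an at least 1.2-fold lower number from compound 1 to compound 3 (0.09 log units; that floor lies within the scatter) carrying wide uncertainty. For compound 3 the estimate in this assay is 8000 nM, within 1500 nM to 30000 nM.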

Compound 3, half-maximal inhibitory concentration: 1470 nM
Compound 3: the middle estimate sits 5.4-fold (0.74 log units) above what was measured; the whole stated range lies above it.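

In this assay, tert-butyl in place of chloro on this aromatic carbon gives an at least 6.8-fold lower number from compound 1 to compound 3 (0.83 log units; beyond the scatter), and it is the only change shown whose effect can be read. Going by these compounds alone, the step from compound 1 to compound 2 cannot be read, so the earlier compounds said nothing about direction, whereas this result shows that the aromatic carbon para to a large group responds to the exchange of its substituent, with the 4-methylpiperazin-1-yl group left in place. The size of the step is only a floor, since compound 1 stands at a limit of the assay and not at a number: the limit of > 10000 nM in this assay, at which 2 of the 3 values shown sit.

The compounds shown leave open whether this drop belongs to tert-butyl itself or would also appear with another group on the same carbon, such as methyl, isopropyl, trifluoromethyl or methoxy. They also leave open how the 4-(tert-butyl)phenyl compound would respond if its 4-methylpiperazin-1-yl group gave way to the (2-(dimethylamino)ethyl)(methyl)amino group of compound 2, to a morpholine or to a longer chain.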